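Cyclohexylcarbamoyl in Place of Morpholin-4-yl: What to Expect

The compounds below may be only part of what the source reports. "The series", "measured", "known", "first", "only" and "open" are said of these compounds alone.

Three compounds share one core and differ only in the group on a saturated chain carbon. Compound 1 `COc1ccc(/C(=C(/CCCl)c2ccccc2)c2ccccc2)cc1` carries chloro there. In a functional assay on MCF7 cells (Homo sapiens) for cytotoxicity, read by MTT assay, with a stated time of 72 h (a higher number here means a weaker inhibitor, a lower number a stronger inhibitor), compound 1 gives only the assay limit, > 50000 nM. Compound 2 `CCOC(=O)C(=O)NCC/C(=C(\c1ccccc1)c1ccc(OC)cc1)c1ccccc1` carries ((ethoxycarbonyl)carbonyl)amino in place of chloro. In this assay compound 2 likewise gives only the limit, > 50000 nM. Compound 3 `COc1ccc(/C(=C(/CCNC(=O)N2CCOCC2)c2ccccc2)c2ccccc2)cc1` carries ((morpholin-4-yl)carbonyl)amino. In this assay compound 3 also gives only the limit, > 50000 nM. Because all three values sit at the limit of > 50000 nM in this assay, at which 3 of the 3 values shown sit, the steps a step that the two limits leave unreadable from compound 1 to compound 2, a step that the two limits leave unreadable from compound 1 to compound 3 and a step that the two limits leave unreadable from compound 2 to compound 3 have no readable size.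

Compound 4 `COc1ccc(/C(=C(/CCNC(=O)C(=O)NC2CCCCC2)c2ccccc2)c2ccccc2)cc1` differs from compound 3 by cyclohexylcarbamoyl in place of morpholin-4-yl on a carbonyl carbon. Among the measured compounds shown here, the steps that bear on this change, a step that the two limits leave unreadable from compound 2 to compound 3 and a step that the two limits leave unreadable from compound 1 to compound 3, give no readable size either, so there is no measured basis for a direction. Compound 4 is therefore expected to remain at or near the limit in this assay, estimated at 50000 nM within the range 20000 nM to 100000 nM. The expected step is a number no higher from compound 3 to compound 4 (the limit leaves the size open).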

Compound 4, half-maximal inhibitory concentration: 12100 nM
For compound 4 the middle estimate is 4.1-fold (0.62 log units) above the measured one, and the stated range ends above it.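

Compound 4 is the only one of the four with a measured number in this assay rather than a limit, so the group on this carbonyl carbon can make a difference (the change gives an at least 4.1-fold lower number from compound 3 to compound 4 (0.61 log units; beyond the scatter)). The same holds against the other two compounds, with cyclohexylamino in place of ethoxy (an at least 4.1-fold lower number from compound 2 to compound 4 (0.61 log units; beyond the scatter)) and with the whole side group in place of chloro (an at least 4.1-fold lower number from compound 1 to compound 4 (0.61 log units; beyond the scatter)). Each size is only a minimum because every starting compound sits at a limit: the limit of > 50000 nM in this assay, at which 3 of the 4 values shown sit.

Cyclohexylcarbamoyl brings a ring of carbon only, a further carbonyl and the amide hydrogen all at once, and the compounds shown do not separate these parts. On these data alone, whether a methylamino or phenylamino group on that same carbonyl carbon would give a similar number also stays open.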